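Compound 4 Loses a Methoxy Group

A few compounds are considered here, and "the series" means these few. Any claim that something is new, unique, unknown or untested is made for them only; others in the source may bear on it.

In a functional assay on MGC-803 cells (Homo sapiens) for antiproliferative activity, read by MTT assay, with a stated time of 48 h (on this read-out lower numbers stand for stronger inhibition and higher numbers for weaker inhibition), compound 1 `COc1ccc(CN(C(=O)CSc2nc3ccccc3s2)c2cc(OC)c(OC)c(OC)c2)cc1O` gives 35 nM while compound 2 `COc1ccc(CN(C(=O)CSc2nc3ccccc3s2)c2cc(OC)c(OC)c(OC)c2)cc1F` gives 416 nM and compound 3 `COc1ccc(CN(C(=O)CSc2nc3ccccc3s2)c2cc(OC)c(OC)c(OC)c2)cc1Br` gives 852 nM as its value. Compound 3 thus has the highest number of the three and the weakest inhibition, and its steps to both others lie beyond the scatter.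

Compound 4 `COc1cc(N(Cc2ccc(Br)cc2)C(=O)CSc2nc3ccccc3s2)cc(OC)c1OC` differs from it on a saturated chain carbon bound to an amide-type nitrogen, where 4-bromophenyl stands in place of 3-bromo-4-methoxyphenyl 4-bromophenyl in place of 3-bromo-4-methoxyphenyl on a saturated chain carbon bound to an amide-type nitrogen in the structure. Going by the values given here, three measured steps bear on this only indirectly: none removes a methoxy group. Swapping hydroxy for fluoro, a large change, gave a 12-fold higher number from compound 1 to compound 2 (1.08 log units; beyond the scatter) and swapping hydroxy for bromo, also large, gave a 24-fold higher number from compound 1 to compound 3 (1.39 log units; beyond the scatter) while swapping fluoro for bromo gave only a 2.0-fold higher number from compound 2 to compound 3 (0.31 log units; beyond the scatter) in a modest move.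

Compound 3 at 852 nM has no hydroxy to lose, so the large steps are a poor guide, and a modest rise in this assay is expected, towards weaker inhibition. The estimated move is a 1.8-fold higher number from compound 3 to compound 4 (0.25 log units; within the scatter) on this reading. Compound 4 is expected near 1500 nM with a range of 500 nM to 4500 nM in this estimate.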

Compound 4, half-maximal inhibitory concentration: 48100 nM
Compound 4: the middle estimate sits 32-fold (1.51 log units) below what was measured; measured number above the stated range.
By their numbers in this assay, from the lowest: compound 1; then compound 2; then compound 3; then compound 4.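

In this assay, replacing 3-bromo-4-methoxyphenyl with 4-bromophenyl on a saturated chain carbon bound to an amide-type nitrogen gives a 56-fold higher number from compound 3 to compound 4 (1.75 log units; beyond the scatter), so this change weakens inhibition sharply and leaves compound 4 the weakest of the four. Going by these compounds alone, the earlier steps altered only one group on this ring while the methoxy group stayed in place, whereas the same ring change measured from the other two compounds gives a 120-fold higher number from compound 2 to compound 4 (2.06 log units; beyond the scatter) and a 1400-fold higher number from compound 1 to compound 4 (3.14 log units; beyond the scatter), showing how far the read-out can travel with the ring at this one place. Nothing available here explains the size of these steps.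

The group names also show that this step is more than a lost methoxy group, since the bromo goes from the 3 of 3-bromo-4-methoxyphenyl to the 4 of 4-bromophenyl, and the compounds shown cannot separate these two parts of the change. From the compounds shown here alone, a compound carrying 3-bromophenyl would be needed to divide them, and whether 3-amino-4-methoxyphenyl would stay near compound 1 or fall towards compound 3 also remains open.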